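This account rests on a few compounds, and the source may have more. Where it says the series, first, only, none or still open, it means among the compounds named here.

Compound 1 `C=C1[C@H](OC(C)=O)C[C@@H](OC(C)=O)C(C)(C)/C=C/[C@@H](C)C(=O)[C@@]2(OC(C)=O)C[C@@](C)(OC(C)=O)[C@H](OC(C)=O)[C@@H]2[C@H]1OC(C)=O` gives 9.5% 
Compound 2 `C=C1[C@H](OC(C)=O)CC(=O)C(C)(C)/C=C/[C@@H](C)C(=O)[C@@]2(OC(C)=O)C[C@@](C)(OC(C)=O)[C@H](OC(C)=O)[C@@H]2[C@H]1OC(C)=O` gives 29.9% 

Both compounds were tested in a functional assay on MCF7 cells (Homo sapiens) for inhibition, read by MTT assay, with a stated time of 72 h, tested at 10 ug/mL; on this read-out lower numbers stand for less inhibition of growth and higher numbers for more inhibition of growth at the one concentration tested. Compound 1 holds the lower of the two numbers (9.5%), and compound 2 reads higher (29.9%), a gap beyond the usual scatter. Compound 1 therefore sits at the low end of what has been measured so far.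

Compound 3 `C=C1[C@H](OC(C)=O)C[C@@H](OC(=O)c2cccnc2)C(C)(C)/C=C/[C@@H](C)C(=O)[C@@]2(OC(C)=O)C[C@@](C)(OC(C)=O)[C@H](OC(C)=O)[C@@H]2[C@H]1OC(C)=O` keeps the core of compound 1 and alters one group: pyridin-3-yl in place of methyl on a carbonyl carbon. Here pyridin-3-yl stands in place of methyl on a carbonyl carbon, which turns an acetoxy into a ((pyridin-3-yl)carbonyl)oxy. Going by the values given here, no measured pair of compounds shows this exchange, so the expectation rests on compound 1 (9.5%) as its starting point, and the data offer no direct guide to the size of the change. In this assay a small rise that stays within the scatter is expected, and the estimated move is a number 5.5 percentage points higher from compound 1 to compound 3 (within the scatter). For compound 3 the estimated value is 15% (expected range 3% to 32%).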

Compound 3, percent growth inhibition at one concentration: 20.3%
For compound 3 the middle estimate is 5.3 percentage points below the measured one; low and high end bracket the measured number.
By their numbers in this assay, from the lowest: compound 1; then compounds 3 and 2 (each within the scatter of the next).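

In this assay, going by these compounds alone, replacing the acetoxy of compound 1 with a ((pyridin-3-yl)carbonyl)oxy gives the first reading of a single exchange at this place: the result is a number 10.8 percentage points higher from compound 1 to compound 3 (beyond the scatter). The position therefore accepts a group carrying a six-membered aromatic ring in place of the methyl on the carbonyl carbon, and growth inhibition at the one concentration tested does not fall, with compound 3 at 20.3%. No measurement at hand bears on what lies behind this modest rise.

With only one aromatic ester at this place, the compounds shown leave open whether the ring nitrogen matters, which a benzoyloxy group or the isomeric ((pyridin-4-yl)carbonyl)oxy group would help to settle. They also leave open whether a longer chain such as butanoyloxy or a free hydroxyl at this place would read like compound 3 or like compound 1, and whether the same exchange at any of the other acetoxy groups on the shared core would produce a similar step.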